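From Bromophenyl to Cyclopropyl: One Swap, Little Data

A few compounds are considered here, and "the series" means these few. Any claim that something is new, unique, unknown or untested is made for them only; others in the source may bear on it.

Compound 1 `O=C1O[C@H]([C@@H](O)Cn2cc(-c3ccc(Br)cc3)nn2)C(OCc2ccccc2)=C1OCc1ccccc1` is the starting point. Within the data shown here, in a functional assay on SW-620 cells (Homo sapiens) for antiproliferative activity, read by MTT assay, with a stated time of 72 h (on this read-out higher numbers stand for weaker inhibition and lower numbers for stronger inhibition), compound 1 gives 3760 nM, the only true number in this small set. Compound 2 `CC(C)(C)OC(=O)N1CCN(C(=S)SCc2cn(C[C@H](O)[C@H]3OC(=O)C(OCc4ccccc4)=C3OCc3ccccc3)nn2)CC1` reads > 100000 nM, which is a limit of the assay and not a number. Compound 3 `COc1ccccc1-c1cn(C/C=C2\OC(=O)C(OCc3ccccc3)=C2OCc2ccccc2)nn1` reads > 100000 nM, which is again a limit.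

Compound 4 `O=C1O[C@H]([C@@H](O)Cn2cc(C3CC3)nn2)C(OCc2ccccc2)=C1OCc1ccccc1` keeps the core of compound 1 and changes one group: cyclopropyl in place of 4-bromophenyl on an aromatic carbon, (cyclopropyl in place of 4-bromophenyl on an aromatic carbon). Among the measured compounds shown here, no pair of measured compounds here shows a change of this kind, so the size of the step is a judgement. For the measured compounds named here, with compound 1 at 3760 nM as the only measured value, weaker inhibition seems the likelier direction in this assay. The expected change, an 8.0-fold higher number from compound 1 to compound 4 (0.90 log units; beyond the scatter), is a large one, beyond the usual scatter. Compound 4 is estimated at 30000 nM, with an expected range from 6000 nM to 100000 nM.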

Compound 4, half-maximal inhibitory concentration: 54200 nM
Estimate against measurement, compound 4: 1.8-fold (0.26 log units) below, within the range that was stated.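

In this assay, among these compounds, a 14-fold higher number from compound 1 to compound 4 (1.16 log units; beyond the scatter) is the first step in this set that can be read, and it shows that the group on this aromatic carbon of the five-membered aromatic ring has a large effect on the read-out, with the rest of the molecule unchanged. Inhibition is weaker after the swap from 4-bromophenyl to cyclopropyl but still measurable, since compound 4 gives a true number, 54200 nM. Such a number cannot be taken for granted in this set: the limit of > 100000 nM in this assay, at which 2 of the 4 values shown sit.

This single swap cannot tell whether the difference comes from the six-membered aromatic ring, from the bromine or from something else. A plain phenyl group or a 4-aminophenyl group on the same carbon would help to tell these apart.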